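The compounds below may be only part of what the source reports. "The series", "measured", "known", "first", "only" and "open" are said of these compounds alone.

In a functional assay on MDA-MB-231 cells (Homo sapiens) for cytotoxicity, read by MTT assay, with a stated time of 72 h (a higher number here means a weaker inhibitor, a lower number a stronger inhibitor), compound 3 `O=C(CN1CCN(c2nnc(Cc3ccncc3)c3ccccc23)CC1)Nc1ccc(F)c(F)c1` gives the lowest number of the series at 0.84 nM, ahead of compound 1 `Cc1ccc(NC(=O)CN2CCN(c3nnc(Cc4ccncc4)c4ccccc34)CC2)c(C)c1` at 240 nM and compound 2 `O=C(CN1CCN(c2nnc(Cc3ccncc3)c3ccccc23)CC1)Nc1c(F)cccc1F` at 1900 nM. Compound 4 `Cc1cccc(Cl)c1NC(=O)CN1CCN(c2nnc(Cc3ccncc3)c3ccccc23)CC1` differs from compound 3 in one place: 2-chloro-6-methylphenyl in place of 3,4-difluorophenyl on an amide-type nitrogen. In words, 2-chloro-6-methylphenyl replaces 3,4-difluorophenyl on an amide-type nitrogen. The measured steps at this same place bear directly on the change. Two were large, a 290-fold lower number from compound 1 to compound 3 (2.46 log units; beyond the scatter) and a 2300-fold lower number from compound 2 to compound 3 (3.35 log units; beyond the scatter), while a 7.9-fold higher number from compound 1 to compound 2 (0.90 log units; beyond the scatter) was modest. Each large step shows how far the number stands from that of compound 3 once 3,4-difluorophenyl is absent, so a large step to a higher number is expected in this assay. For compound 4 the estimated value is 800 nM, with an expected range of 120 nM to 4000 nM. The expected change is a 950-fold higher number from compound 3 to compound 4 (2.98 log units; beyond the scatter).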

Compound 4, half-maximal inhibitory concentration: 2670 nM
Beside the measured number, compound 4's estimate is 3.3-fold (0.52 log units) below it; measured number inside the range.
By their numbers in this assay, from the lowest: compound 3; then compound 1; then compounds 2 and 4 (each within the scatter of the next).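

With 2-chloro-6-methylphenyl on the amide-type nitrogen, this assay shows a 3200-fold higher number from compound 3 to compound 4 (3.50 log units; beyond the scatter) and also an 11-fold higher number from compound 1 to compound 4 (1.05 log units; beyond the scatter), so compound 3 stays far apart from all three other aryl groups. The new group and 2,6-difluorophenyl are not told apart, with a 1.4-fold higher number from compound 2 to compound 4 (0.15 log units; within the scatter) and thus within the scatter. No evidence is available to explain these differences. As far as these compounds go, whether compound 3's low number needs both fluorines stays open, as does the outcome with 4-fluorophenyl, 3,4-dichlorophenyl or an aminophenyl group at this nitrogen.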